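Phenyl for Vinyl on the Chain: Rat Plasma Half-Life

A few compounds are considered here, and "the series" means these few. Any claim that something is new, unique, unknown or untested is made for them only; others in the source may bear on it.

Measured so far in an ADME assay on the whole organism (plasma) for metabolic stability, with Rattus norvegicus as the target; on this read-out lower numbers stand for a shorter-lived compound and higher numbers for a longer-lived compound:
Compound 1, `C=CCCCC=C(c1cc(Br)c(OC)c(C(=O)OC)c1)c1cc(Br)c(OC)c(C(=O)OC)c1`: 0.975 h
Compound 2, `C=CCCCC=C(c1cc(Cl)c(OC)c(C(=O)OC)c1)c1cc(Cl)c(OC)c(C(=O)OC)c1`: 0.655 h
Compound 3, `COC(=O)c1cc(C(=CCCCc2ccccc2)c2cc(Br)c(OC)c(C(=O)OC)c2)cc(Br)c1OC`: 0.917 h

Compound 3 arises from compound 1 by a single change, (phenyl in place of vinyl on a saturated chain carbon, three bonds along the chain from a double-bonded chain carbon), and the step this made was a 1.1-fold lower number from compound 1 to compound 3 (0.03 log units; within the scatter). The values of compound 2 and compound 3 lie within the usual scatter of each other, as do those of compound 2 and compound 1. How the core of compound 2 differs from the core of compound 1 is not broken down here.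

Compound 4, `COC(=O)c1cc(C(=CCCCc2ccccc2)c2cc(Cl)c(OC)c(C(=O)OC)c2)cc(Cl)c1OC`, is not yet measured; it arises from compound 2 by the same kind of change, (phenyl in place of vinyl on a saturated chain carbon, three bonds along the chain from a double-bonded chain carbon), at the same place on the chain. Resting on the step of a 1.1-fold lower number from compound 1 to compound 3 (0.03 log units; within the scatter), compound 4 is expected to show a step of a 1.1-fold lower number from compound 2 to compound 4 (0.04 log units; within the scatter) in this assay. Compound 4 is therefore estimated at 0.6 h, most likely between 0.35 h and 1 h.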

Compound 4, half-life: 1.28 h
Compound 4: the middle estimate sits 2.1-fold (0.33 log units) below what was measured; measured number above the stated range.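

Putting phenyl in place of vinyl on the core of compound 2 gave a 2.0-fold higher number from compound 2 to compound 4 (0.29 log units; within the scatter). Set beside the earlier step, the two cores cannot be told apart, so the change carries over as far as these numbers can show: the same change on two cores in this assay, a 1.1-fold lower number (0.03 log units; within the scatter) from compound 1 to compound 3 and a 2.0-fold higher number (0.29 log units; within the scatter) from compound 2 to compound 4, 2.1-fold (0.32 log units) apart, within the scatter of two such steps. Neither step shows that the change truly alters how long a compound lasts in this assay, and two pairs cannot establish that it would behave alike on every core in this series.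

The compounds shown leave open what other groups would do at this place on the chain, such as an amine, a carboxylic acid or a longer saturated chain. They also leave open how phenyl in place of vinyl would behave on any further core.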